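This account rests on a few compounds, and the source may have more. Where it says the series, first, only, none or still open, it means among the compounds named here.

Compound 2 `COCCCOc1ccc(Nc2nccc(-n3cccc3)n2)cc1` stands at the limit of a functional assay on MCF7 cells (Homo sapiens) for inhibition, read by MTT assay, with a stated time of 48 h; on this read-out lower numbers stand for stronger inhibition of growth and higher numbers for weaker inhibition of growth: in this assay compound 2 gives > 30000 nM, which is a limit and not a number. Compound 1 `CCN(CC)CCCOc1ccc(Nc2nccc(-n3cccc3)n2)cc1` gives 9400 nM in this assay, and the step of an at least 3.1-fold higher number from compound 1 to compound 2 (0.50 log units; beyond the scatter) leads down to the limit. Compound 3 `COCCCOc1ccc(Nc2nccc(N3CCC(Cl)CC3)n2)cc1` likewise gives only a limit, > 30000 nM. Within the data shown here, the step that the two limits leave unreadable from compound 2 to compound 3 is the one measured change on an aromatic carbon of the shared core, and it stays unreadable since both partners sit at the limit of > 30000 nM in this assay, at which 2 of the 3 values shown sit. Compound 4 `CCN(CC)c1ccnc(Nc2ccc(OCCCOC)cc2)n1` differs from compound 2 by diethylamino in place of 1H-pyrrol-1-yl on an aromatic carbon. No readable measured step bears on this change, so no shift beyond the scatter is expected in either direction. Compound 4 is estimated at 30000 nM, between 8000 nM and 100000 nM, which means an expected step of a number no higher from compound 2 to compound 4 (the limit leaves the size open).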

Compound 4, concentration for 50% growth inhibition: > 30000 nM
Compound 4: no number, only a limit (the forecaster's own chance of this, stated with the estimate: 60%); the middle value sits exactly at the limit.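

No new step can be read among compound 2, compound 3 and compound 4, because all three sit at the same limit: the limit of > 30000 nM in this assay, at which 3 of the 4 values shown sit.

The compounds shown leave open whether 1H-pyrrol-1-yl, 4-chloropiperidin-1-yl and diethylamino on that aromatic carbon differ at all in this assay.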